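Trimming the Amide Side Chain of Compound 2

A few compounds are considered here, and "the series" means these few. Any claim that something is new, unique, unknown or untested is made for them only; others in the source may bear on it.

Compound 2 `COc1cccc(CN(CCCN2CCN(C)CC2)C(=O)c2c[nH]c3nc(-c4cn[nH]c4)ccc23)c1` carries the highest number of the three measured compounds in an assay on isolated protein for inhibition of Rho-associated protein kinase 2 (Homo sapiens) (a lower number here means a stronger inhibitor, a higher number a weaker inhibitor), at 62 nM. Its nearest neighbour is compound 3 `COc1cccc(CNC(=O)c2cc3ccc(-c4cn[nH]c4)nc3n2CCCO)c1`, which in this assay gives 24 nM; furthest off stands compound 1 `COc1cccc(CN(C(=O)c2c[nH]c3nc(-c4cn[nH]c4)ccc23)C2CC2)c1`, which gives 6 nM. Going by the values given here, the single exchange of cyclopropyl for 3-(4-methylpiperazin-1-yl)propyl on an amide-type nitrogen produced a 10-fold higher number from compound 1 to compound 2 (1.01 log units; beyond the scatter). The unmeasured compound 4 `CCN(Cc1cccc(OC)c1)C(=O)c1c[nH]c2nc(-c3cn[nH]c3)ccc12` differs from compound 2 by hydrogen in place of (4-methylpiperazin-1-yl)methyl on a saturated chain carbon, two bonds along the chain from an amide-type nitrogen, so that an ethyl remains on the amide-type nitrogen, a small group once more as in compound 1. Among the compounds with values here, only one measured step bears on this change, and it was large in the direction of a higher number when the long chain went in; removing it is therefore expected to give a large step the other way, back toward the figure of compound 1, with the reservation that ethyl is not cyclopropyl and the return may be incomplete. Compound 4 is expected at 10 nM, within 4 nM to 30 nM, which would mean a 6.2-fold lower number from compound 2 to compound 4 (0.79 log units; beyond the scatter).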

Compound 4, half-maximal inhibitory concentration: 19 nM
For compound 4 the middle estimate is 1.9-fold (0.28 log units) below the measured one; the measured number falls inside the stated range.
By their numbers in this assay, from the lowest: compound 1; then compounds 4 and 3 (each within the scatter of the next); then compound 2.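

In this assay, cutting the chain back to ethyl gives a 3.3-fold lower number from compound 2 to compound 4 (0.51 log units; beyond the scatter), so removing the (4-methylpiperazin-1-yl)methyl recovers only part of the earlier loss, a 10-fold higher number from compound 1 to compound 2 (1.01 log units; beyond the scatter). Going by these compounds alone, the rest of that gap lies in the small group itself: ethyl in place of cyclopropyl on the amide-type nitrogen gives a 3.2-fold higher number from compound 1 to compound 4 (0.50 log units; beyond the scatter), a contribution that the single earlier step could not separate from that of the long chain. No measurement at hand explains either step.

The compounds shown leave open how methyl, isopropyl or cyclobutyl on the amide-type nitrogen would compare with ethyl and cyclopropyl. They also leave open whether a plain propyl or a 3-hydroxypropyl there would fall nearer compound 4 or compound 2, which would separate the effect of the chain from that of the piperazine at its end.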